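The compounds below may be only part of what the source reports. "The series", "measured", "known", "first", "only" and "open" are said of these compounds alone.

Measured in a functional assay on DU-145 cells (Homo sapiens) for cytotoxicity, read by sulforhodamine B assay, with a stated time of 48 h; on this read-out higher numbers stand for weaker inhibition of growth and lower numbers for stronger inhibition of growth:
compound 1 `N#Cc1ccc(Nc2nc(Oc3ccnc4ccccc34)nc(N3CCN(c4ccccc4Cl)CC3)n2)cc1C(F)(F)F` gives 92600 nM
compound 2 `N#Cc1ccc(Nc2nc(Oc3ccnc4ccccc34)nc(N3CCN(c4ccc(F)cc4)CC3)n2)cc1C(F)(F)F` gives > 100000 nM as a limit, not a number
compound 3 `CN1CCN(c2nc(Nc3ccc(C#N)c(C(F)(F)F)c3)nc(Oc3ccnc4ccccc34)n2)CC1` gives 51200 nM

Compound 1 has one neighbour with a true number, and the gap is small: a 1.8-fold lower number from compound 1 to compound 3 (0.26 log units; within the scatter) is all that separates the two. Compound 2 stands at > 100000 nM, which is a limit of the assay.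

Next comes compound 4 `N#Cc1ccc(Nc2nc(Oc3ccnc4ccccc34)nc(N3CCN(c4cccc(C(F)(F)F)c4)CC3)n2)cc1C(F)(F)F`, with 3-(trifluoromethyl)phenyl in place of 2-chlorophenyl on an amine nitrogen in a ring, (3-(trifluoromethyl)phenyl in place of 2-chlorophenyl on an amine nitrogen in a ring).

Two further measured steps concern the same substituent. With 4-fluorophenyl in place of 2-chlorophenyl the result is an at least 1.0-fold higher number from compound 1 to compound 2 (0.03 log units; that floor lies within the scatter), and with methyl in place of 4-fluorophenyl it is an at least 1.9-fold lower number from compound 2 to compound 3 (0.29 log units; that floor lies within the scatter). Within the data shown here, no step at this nitrogen has yet left the scatter, so none is expected here, and the expected outcome is a 1.2-fold lower number from compound 1 to compound 4 (0.06 log units; within the scatter) in this assay. Compound 4 keeps a substituted phenyl there, like compound 1 at 92600 nM, so the estimate stays close to that value. A report of a limit alone for compound 4 would be no surprise.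

For compound 4 the expected value is 80000 nM, with an estimated range from 40000 nM to 130000 nM.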

Compound 4, concentration for 50% growth inhibition: 38700 nM
The estimate for compound 4 lay 2.1-fold (0.32 log units) above the measured number; measured number outside the range, below it.
By their numbers in this assay, from the lowest: compounds 4, 3 and 1 (each within the scatter of the next, the first and the last beyond it). At a limit, above all of these: compound 2.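

Among these compounds, at the amine nitrogen in the ring, a 2.4-fold lower number from compound 1 to compound 4 (0.38 log units; beyond the scatter) is the first step between two true numbers in this assay to leave the scatter, so the choice of substituted phenyl at this place can register, if only modestly. A phenyl ring as such does not separate the compounds, since a 1.3-fold lower number from compound 3 to compound 4 (0.12 log units; within the scatter) leaves the methyl compound and the 3-(trifluoromethyl)phenyl compound indistinguishable. Compound 2 carries a limit and not a number, so an at least 2.5-fold lower number from compound 2 to compound 4 (0.41 log units; beyond the scatter) is only a floor: the limit of > 100000 nM in this assay, at which 1 of the 4 values shown sits.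

Compounds 1 and 4 differ in both the substituent and its place on the phenyl ring, so it remains open which of the two accounts for the step, and a 3-chlorophenyl group on this nitrogen would help to separate them. Also open, from the compounds shown here alone, is how this nitrogen responds to groups of another kind, such as an acetyl group or a longer chain ending in a carboxylic acid, and whether the step carries over to any other cell line.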